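The compounds below may be only part of what the source reports. "The series", "measured", "known", "first", "only" and "open" are said of these compounds alone.

Compound 1 `Cc1ccc(Nc2ncc(Cl)c(Nc3ccccc3C)n2)cc1`: > 100000 nM (a limit)
Compound 2 `Cc1ccccc1Nc1nc(Nc2ccc(N3CCN(C)CC3)cc2)ncc1Cl`: 6510 nM
Compound 3 `Cc1ccccc1Nc1nc(Nc2ccc(N3CCCCC3)cc2)ncc1Cl`: 5690 nM

In an ADME assay on L02 cells (Homo sapiens) for inhibition, read by CCK-8 assay, with a stated time of 48 h (a lower number here means a stronger inhibitor of growth, a higher number a weaker inhibitor of growth), compound 1 gives > 100000 nM, which is a limit of the assay and not a number. Among the measured compounds shown here, compound 3 gives 5690 nM and stands level with compound 2, the only other compound with a number, since the gap is within the scatter: a 1.1-fold lower number from compound 2 to compound 3 (0.06 log units; within the scatter).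

Compound 4 `Cc1ccccc1Nc1nc(Nc2ccc(N3CCCN(C)CC3)cc2)ncc1Cl` carries 4-methyl-1,4-diazepan-1-yl in place of piperidin-1-yl on an aromatic carbon.

Two kinds of measured step bear on this change. Replacing methyl with either ring gave a large step, an at least 15-fold lower number from compound 1 to compound 2 (1.18 log units; beyond the scatter) and an at least 17-fold lower number from compound 1 to compound 3 (1.24 log units; beyond the scatter). Exchanging one ring for the other, however, made no difference beyond the scatter, as the step between compound 2 and compound 3 shows. The new ring is a further exchange of this second kind, so no step beyond the scatter is expected in this assay. The expected step is a 1.1-fold higher number from compound 3 to compound 4 (0.02 log units; within the scatter). The estimated value for compound 4 is 6000 nM. The estimated range for compound 4 runs from 2500 nM to 15000 nM.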

Compound 4, concentration for 50% growth inhibition: 1240 nM
Compound 4: middle estimate off by 4.8-fold (0.68 log units), on the high side; the whole stated range lies above it.
By their numbers in this assay, from the lowest: compound 4; then compounds 3 and 2 (each within the scatter of the next). At a limit, above all of these: compound 1.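

In this assay, the ring at this position, on an aromatic carbon para to a large group, proves not to be freely exchangeable. The exchange between piperidin-1-yl and 4-methylpiperazin-1-yl stayed within the scatter, yet 4-methyl-1,4-diazepan-1-yl gives a 4.6-fold lower number from compound 3 to compound 4 (0.66 log units; beyond the scatter) and a 5.3-fold lower number from compound 2 to compound 4 (0.72 log units; beyond the scatter) and so separates itself from both six-membered rings. Set against methyl, the seven-membered ring gives an at least 80-fold lower number from compound 1 to compound 4 (1.90 log units; beyond the scatter) but this step is only a bound, as compound 1 stands at a limit and not at a number: the limit of > 100000 nM in this assay, at which 1 of the 4 values shown sits.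

The compounds shown leave open whether the lower number follows the larger ring, the second nitrogen or the methyl on that nitrogen. An unsubstituted 1,4-diazepan-1-yl and a morpholin-4-yl group would bear on that question, and an open-chain amine such as dimethylamino would show whether a ring is needed here at all.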